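Swapping the aryl group on a Kir channel activator

This account rests on a few compounds, and the source may have more. Where it says the series, first, only, none or still open, it means among the compounds named here.

Measured so far in an assay on HEK293 cells for activation of Kir3.1/Kir3.2 (Homo sapiens), read by thallium flux; on this read-out higher numbers stand for larger maximal responses and lower numbers for smaller maximal responses:
compound 1 `Cc1cc(NC(=O)Cn2nnc(-c3ccccn3)n2)n(C2CCCCC2)n1` gives 81%
compound 2 `Cc1cc(NC(=O)Cn2nnc(-c3cc(Cl)cc(Cl)c3)n2)n(C2CCCCC2)n1` gives 82%
compound 3 `Cc1cc(NC(=O)Cn2nnc(-c3cccc(F)c3)n2)n(C2CCCCC2)n1` gives 96%

Compound 3 stands highest of the three, with compound 2 closest to it and compound 1 furthest, and both gaps lie beyond the scatter. The untested compound 4 `Cc1ccc(-c2nnn(CC(=O)Nc3cc(C)nn3C3CCCCC3)n2)cc1` keeps the shared core of compound 3 and changes only the aryl group: 4-methylphenyl in place of 3-fluorophenyl on an aromatic carbon.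

Within the data shown here, two measured steps bear on this position. Replacing pyridin-2-yl with 3-fluorophenyl gave a number 15 percentage points higher from compound 1 to compound 3 (beyond the scatter), and replacing 3,5-dichlorophenyl with 3-fluorophenyl gave a number 14 percentage points higher from compound 2 to compound 3 (beyond the scatter). Both show that the aryl group at this carbon moves the maximal response by a modest amount, and that 3-fluorophenyl sits at the top of what has been seen. Among the measured compounds shown here, no measured step involves 4-methylphenyl, so its direction is uncertain; a small drop back toward the level of compound 1 and compound 2, or no change beyond the scatter, seems most likely.

Compound 4 is therefore expected to give 88% in this assay, within a range from 75% to 100%. This estimate means a step of a number 8 percentage points lower from compound 3 to compound 4 (within the scatter).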

Compound 4, largest response reached (Emax), in percent of the reference or control that the assay uses: 86%
Beside the measured number, compound 4's estimate is 2 percentage points above it, and the stated range covers the measured number.
By their numbers in this assay, from the lowest: compounds 1, 2, 4 and 3 (each within the scatter of the next, the first and the last beyond it).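

In this assay the swap to 4-methylphenyl gives a number 10 percentage points lower from compound 3 to compound 4 (within the scatter) while the steps from the other two aryl groups give a number 4 percentage points higher from compound 2 to compound 4 (within the scatter) and a number 5 percentage points higher from compound 1 to compound 4 (within the scatter) so compound 4 cannot be told apart from any of the other three. The aryl groups at this carbon therefore no longer fall into two separate levels: compound 3 remains beyond the scatter of compound 1 and compound 2, but compound 4 overlaps with all of them. Nothing available explains this spread of values.

Still open, going by these compounds, is whether 3-methylphenyl or 4-fluorophenyl would separate the effect of the group from that of its place on the ring. Also open, on these data alone, is whether an amine or a carboxylic acid on the ring would take the response outside this band.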